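This account rests on a few compounds, and the source may have more. Where it says the series, first, only, none or still open, it means among the compounds named here.

Compound 1 `COC(=O)/C=C/c1cccc(N(Cc2ccc(/C=C/c3ccccn3)cc2)C(=O)C2CCCCC2)c1` gives 309 nM in an assay on isolated protein with Bile acid receptor (Homo sapiens) as the target; on this read-out higher numbers stand for an effect only at larger amounts of compound and lower numbers for an effect already at smaller amounts.
Compound 2 `COC(=O)/C=C/c1cccc(NC(=O)C2CCCCC2)c1` gives > 1000 nM in this assay, which is a limit of the assay and not a number.
Compound 3 `COC(=O)/C=C/c1cccc(N(C)C(=O)C2CCCCC2)c1` gives > 1000 nM in this assay, likewise a limit and not a number.

Compound 3 thus sits at the limit of > 1000 nM in this assay, at which 2 of the 3 values shown sit, so only a bound is known for it. Compound 4 `COC/C=C/c1ccc(CN(C(=O)C2CCCCC2)c2cccc(/C=C/C(=O)OC)c2)cc1` differs from it by 4-(3-methoxyprop-1-en-1-yl)phenyl in place of hydrogen on a saturated chain carbon bound to an amide-type nitrogen. Among the measured compounds shown here, the one measured step, a step that the two limits leave unreadable from compound 2 to compound 3, runs between two limits and tells nothing about size or direction. For the measured compounds named here, no step connects compound 3 and compound 4 directly; the nearest guide is compound 1, which carries a different large group on the same saturated chain carbon and gives 309 nM, a value clearly inside the measurable range. On that basis compound 4 is expected to move from the limit into the measurable range, an estimated step of an at least 2.5-fold lower number from compound 3 to compound 4 (0.39 log units; beyond the scatter) in this assay. The expected value for compound 4 in this assay is 400 nM, with a range from 150 nM to 1200 nM.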

Compound 4, half-maximal effective concentration: 233 nM
For compound 4 the middle estimate is 1.7-fold (0.23 log units) above the measured one, and the stated range covers the measured number.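

Placing 4-(3-methoxyprop-1-en-1-yl)phenyl on the saturated chain carbon bound to the amide-type nitrogen gives an at least 4.2-fold lower number from compound 3 to compound 4 (0.63 log units; beyond the scatter) in this assay, so a large group at this position can bring a compound into the measurable range. With methoxymethyl in place of pyridin-2-yl on the double-bonded chain carbon, there is a 1.3-fold lower number from compound 1 to compound 4 (0.12 log units; within the scatter), so the pyridine ring of compound 1 is not required for a measurable value. The first step is only a bound because compound 3 sits at a limit: the limit of > 1000 nM in this assay, at which 2 of the 4 values shown sit.

The compounds shown leave open how much of the added group is needed, for example whether a plain phenyl would be enough. They also leave open how an amine or a carboxylic acid would behave in place of methoxymethyl.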